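Bromo on the Indole-Type Core: One Change, Two Scaffolds

This account rests on a few compounds, and the source may have more. Where it says the series, first, only, none or still open, it means among the compounds named here.

Compound 1, with the structure `COc1cc(/C(Cl)=C/C=C(\C#N)C(=O)c2c[nH]c3ccccc23)cc(OC)c1OC`, was tested in a functional assay for inhibition, with a stated time of 5 min, tested at 1 mM (on this read-out lower numbers stand for less inhibition and higher numbers for more inhibition at the one concentration tested (going by the name of the read-out)), where compound 1 gives 59.1%. Compound 2, `COc1cc(/C(Cl)=C/C=C(\C#N)C(=O)c2c[nH]c3ccc(Br)cc23)cc(OC)c1OC`, differs from compound 1 only by bromo in place of hydrogen on an aromatic carbon. In this assay compound 2 gives 50%, so that the change produced a number 9.1 percentage points lower from compound 1 to compound 2 (within the scatter).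

Compound 3, `N#C/C(=C\C=C(/Cl)c1ccc(Br)cc1)C(=O)c1c[nH]c2ccccc12`, carries a different left-hand part; the difference between the core of compound 1 and the core of compound 3 is not broken down here. In this assay compound 3 gives 65.5%, which stands within the scatter of compound 1 and beyond the scatter of compound 2.

Compound 4, `N#C/C(=C\C=C(/Cl)c1ccc(Br)cc1)C(=O)c1c[nH]c2ccc(Br)cc12`, has not yet been measured. It differs from compound 3 by bromo in place of hydrogen on an aromatic carbon, the same change that turns compound 1 into compound 2, at a place described in the same words. Among the compounds shown this change occurs twice in all. For the measured compounds named here, because the only measured instance of this change gave a number 9.1 percentage points lower from compound 1 to compound 2 (within the scatter), a step of similar size is expected here, and compound 4 is estimated to lie a number 9.5 percentage points lower from compound 3 to compound 4 (within the scatter) relative to compound 3. On that basis compound 4 is expected to give about 56% in this assay, with a plausible range from 40% to 72%, since a single prior step cannot fix the number more closely.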

Compound 4, a percentage reported as inhibition, at one concentration (the size of the read-out at that concentration, not a potency): 83.6%
Estimate against measurement, compound 4: 27.6 percentage points below; measured number outside the range, above it.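

In this assay, bromo in place of hydrogen on an aromatic carbon of the core of compound 3 gave a number 18.1 percentage points higher from compound 3 to compound 4 (beyond the scatter). The change therefore did not carry over from one core to the other with the same size or direction, and the step seen on the core of compound 1 proved a poor guide to the step on the core of compound 3: the same change on two cores in this assay, a number 9.1 percentage points lower (within the scatter) from compound 1 to compound 2 and a number 18.1 percentage points higher (beyond the scatter) from compound 3 to compound 4, 27.2 percentage points apart, beyond the scatter of two such steps. This shows that the outcome of adding bromo at this place depends on the rest of the molecule in this pair of cores, but it does not show which part of the left-hand portion is responsible or why, and two pairs measured at a single concentration give no general rule for the series and no measure of potency.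

The compounds shown leave open whether a different group on the same aromatic carbon, such as an amine or a carboxylic acid, would also behave differently on the two cores, or whether this divergence is particular to bromo. They also leave open how the same change would behave on a third left-hand part, such as one carrying a longer chain, and whether it would follow compound 1 and compound 2 or compound 3 and compound 4.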